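A few compounds are considered here, and "the series" means these few. Any claim that something is new, unique, unknown or untested is made for them only; others in the source may bear on it.

Three compounds share one core and differ only in the aryl group on the amide carbonyl. Compound 1 `Cc1ccc(C(=O)Nc2ccc(C(=O)/C=C/c3nc(C)c(C)nc3C)cc2)cc1` gives in a functional assay on HepG2 cells (Homo sapiens) for antiproliferative activity, read by CCK-8 assay, with a stated time of 72 h (a lower number here means a stronger inhibitor, a higher number a weaker inhibitor), a value of 5450 nM, compound 2 `COc1cc(C(=O)Nc2ccc(C(=O)/C=C/c3nc(C)c(C)nc3C)cc2)cc(OC)c1OC` gives 4860 nM, and compound 3 `Cc1nc(C)c(/C=C/C(=O)c2ccc(NC(=O)c3ccc(F)cc3F)cc2)nc1C` gives 2990 nM. Compound 3 has the lowest of the three numbers, yet both compound 1 and compound 2 sit within the scatter of it, so no order among them can be claimed. For the measured compounds named here, the one measured step, a 1.8-fold lower number from compound 1 to compound 3 (0.26 log units; within the scatter), shows that exchanging the aryl group on the carbonyl carbon moved the number little. Compound 4 `Cc1nc(C)c(/C=C/C(=O)c2ccc(NC(=O)c3ccccc3F)cc2)nc1C` carries the change (hydrogen in place of fluoro on an aromatic carbon). This edit touches the same aryl group as the step from compound 1 to compound 3, and that step stayed within the scatter, so compound 4 is expected to show a step of a 1.2-fold higher number from compound 3 to compound 4 (0.07 log units; within the scatter) that is no larger than the scatter in this assay, in no settled direction. Compound 4 is therefore estimated at 3500 nM, with a range from 1500 nM to 8000 nM.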

Compound 4, half-maximal inhibitory concentration: 2040 nM
Beside the measured number, compound 4's estimate is 1.7-fold (0.23 log units) above it; low and high end bracket the measured number.
By their numbers in this assay, from the lowest: compounds 4, 3, 2 and 1 (each within the scatter of the next, the first and the last beyond it).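

At this aromatic carbon, meta to a fluoro group and para to a large group, hydrogen in place of fluoro gives a 1.5-fold lower number from compound 3 to compound 4 (0.17 log units; within the scatter) in this assay and so leaves the number within the scatter, with the second fluoro group of the 2,4-difluorophenyl ring making no clear difference here. For the compounds shown here, the exchange of 4-methylphenyl for 2-fluorophenyl on the carbonyl carbon gives a 2.7-fold lower number from compound 1 to compound 4 (0.43 log units; beyond the scatter) and is the first step in this set to pass beyond the scatter, though only modestly. Nothing available explains either step.

The compounds shown vary only the aryl group on the amide carbonyl, so they say nothing about changes elsewhere in the shared core. From the compounds shown here alone, how an amine or a carboxylic acid on that aryl group would read in this assay remains open.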